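Methyl on the saturated ring carbon: compound 2 to compound 3

This account rests on a few compounds, and the source may have more. Where it says the series, first, only, none or still open, it means among the compounds named here.

Among the measured compounds shown here, compound 2 `O=C1NCCN(c2cccc(Br)n2)N1` stands with the highest of the two numbers measured so far; in a functional assay on cells for inhibition of Polyunsaturated fatty acid 5-lipoxygenase (Homo sapiens) (on this read-out higher numbers stand for weaker inhibition and lower numbers for stronger inhibition), compound 2 gives 4600 nM. For the measured compounds named here, its only neighbour, compound 1 `Cc1cccc(N2CC(C)NC(=O)N2)n1`, gives 1700 nM in this assay, a gap beyond the scatter, but compound 1 differs from compound 2 in two places at once. Compound 3 `CC1CN(c2cccc(Br)n2)NC(=O)N1` differs from compound 2 by methyl in place of hydrogen on a saturated ring carbon. Going by the values given here, no single step of this kind is known here; the lower number of compound 1, at 1700 nM, points toward a modest improvement, possibly within the scatter. Compound 3 is expected at 2700 nM, with a range of 1100 nM to 6500 nM, an expected step of a 1.7-fold lower number from compound 2 to compound 3 (0.23 log units; within the scatter).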

Compound 3, half-maximal inhibitory concentration: 3100 nM
For compound 3 the middle estimate is 1.1-fold (0.06 log units) below the measured one; the range from low to high includes it.
By their numbers in this assay, from the lowest: compounds 1, 3 and 2 (each within the scatter of the next, the first and the last beyond it).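

In this assay, among the compounds shown here, the single change of methyl in place of hydrogen on a saturated ring carbon gives a 1.5-fold lower number from compound 2 to compound 3 (0.17 log units; within the scatter), so this position takes a methyl without a step beyond the scatter. Bromo in place of methyl on an aromatic carbon gives a 1.8-fold higher number from compound 1 to compound 3 (0.26 log units; within the scatter), so neither single change alone reaches beyond the scatter, although the two earlier compounds lie beyond it. No measurement here speaks to the reason for either step. Open remain a longer chain, an amine or a carboxylic acid on this ring carbon, and a nitrile in place of bromo on the aromatic carbon.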